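This account rests on a few compounds, and the source may have more. Where it says the series, first, only, none or still open, it means among the compounds named here.

In a physicochemical assay for solubility, measured as kinetic solubility (a lower number here means a less soluble compound, a higher number a more soluble compound), two compounds have been measured so far:

compound 1 `C[C@H](NC(=O)c1cc(C(F)(F)F)nn1C)c1nc(-c2ccnc(C(F)F)c2)no1`: 178000 nM
compound 2 `CNc1cc(-c2noc([C@H](C)NC(=O)c3cc(C(F)(F)F)nn3C)n2)ccn1`: 143000 nM

Compound 2, at 143000 nM, lies within the usual scatter of compound 1, so the two cannot be ranked. The next compound is compound 3 `C[C@H](NC(=O)c1cc(C(F)(F)F)nn1C)c1nc(-c2ccnc(C(F)(F)F)c2)no1`. It keeps the rest of compound 2 but carries trifluoromethyl in place of methylamino on an aromatic carbon, next to the ring nitrogen (trifluoromethyl in place of methylamino on an aromatic carbon).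

Within the data shown here, only one measured step bears on this change. With methylamino in place of difluoromethyl on an aromatic carbon, it was a 1.2-fold lower number from compound 1 to compound 2 (0.10 log units; within the scatter). Among the measured compounds shown here, that is thin evidence, since it is a single pair and no measured compound yet carries trifluoromethyl at this position. On that basis, no step beyond the scatter is expected in this assay, and no direction can be called with confidence. The expected change is a 1.1-fold lower number from compound 2 to compound 3 (0.04 log units; within the scatter). The estimate for compound 3 is 130000 nM, with an expected range of 60000 nM to 220000 nM.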

Compound 3, solubility: 58000 nM
Beside the measured number, compound 3's estimate is 2.2-fold (0.35 log units) above it, and the stated range ends above it.
By their numbers in this assay, from the lowest: compound 3; then compounds 2 and 1 (each within the scatter of the next).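

In this assay the group on the aromatic carbon next to the ring nitrogen turns out to matter, which compounds 1 and 2 alone gave no sign of, as their values lie within the scatter of each other. Trifluoromethyl in place of methylamino gives a step beyond the scatter (a 2.5-fold lower number from compound 2 to compound 3 (0.39 log units; beyond the scatter)), so this position can move the number after all. The smaller-looking edit, fluoro in place of hydrogen on the difluoromethyl carbon, also gives a step beyond the scatter (a 3.1-fold lower number from compound 1 to compound 3 (0.49 log units; beyond the scatter)), so methylamino and difluoromethyl stand together here while trifluoromethyl stands apart. Nothing measured here explains why trifluoromethyl parts from the other two groups.

Among these compounds, with only three groups at this position, it stays open whether the drop belongs to trifluoromethyl alone or would also appear with other groups, such as a chlorine atom, a methyl or a methoxy. Going by these compounds, it is also open whether the same swap would give a similar step with a different amide half on the shared core.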